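Testing a 3-Fluorophenyl Swap in a Series at Its Limit

A few compounds are considered here, and "the series" means these few. Any claim that something is new, unique, unknown or untested is made for them only; others in the source may bear on it.

Of the compounds shown here, three built on one shared core have been tested so far in a functional assay on DU-145 cells (Homo sapiens) for antiproliferative activity, read by MTT assay, with a stated time of 48 h; on this read-out higher numbers stand for weaker inhibition and lower numbers for stronger inhibition: compound 1 `C/C(=C\CC/C(C)=C/CC[C@@H]1[C@@]2(C)CCC(=O)C(C)(C)[C@H]2CC[C@@]1(C)O)CC/C=C(\C)C(=O)OCc1cn(-c2ccc([N+](=O)[O-])cc2)nn1`, compound 2 `C/C(=C\CC/C(C)=C/CC[C@@H]1[C@@]2(C)CCC(=O)C(C)(C)[C@H]2CC[C@@]1(C)O)CC/C=C(\C)C(=O)OCc1cn(-c2ccccc2Br)nn1` and compound 3 `C/C(=C\CC/C(C)=C/CC[C@@H]1[C@@]2(C)CCC(=O)C(C)(C)[C@H]2CC[C@@]1(C)O)CC/C=C(\C)C(=O)OCc1cn(-c2ccc(Br)cc2)nn1`. Compound 1 gives > 150000 nM, which is a limit and not a number. Compound 2 gives > 150000 nM, again a limit. Compound 3 gives > 150000 nM, also a limit, so it has no exact place on the scale. The whole series therefore stands at one point: the limit of > 150000 nM in this assay, at which 3 of the 3 values shown sit.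

Compound 4 `C/C(=C\CC/C(C)=C/CC[C@@H]1[C@@]2(C)CCC(=O)C(C)(C)[C@H]2CC[C@@]1(C)O)CC/C=C(\C)C(=O)OCc1cn(-c2cccc(F)c2)nn1` keeps the shared core and carries 3-fluorophenyl in place of 4-bromophenyl on an aromatic nitrogen.

The measured steps that bear on this change are swaps at the same place. One is a step that the two limits leave unreadable from compound 2 to compound 3, and the other is a step that the two limits leave unreadable from compound 1 to compound 3. Neither has a readable size, and none of the three groups tried so far has produced a number. They give no ground for expecting a shift in either direction, so no step beyond the usual scatter is expected. The expected step is a number no higher from compound 3 to compound 4 (the limit leaves the size open). For compound 4 the estimated value is 150000 nM, with an expected range from 40000 nM to 300000 nM.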

Compound 4, half-maximal inhibitory concentration: > 150000 nM
Compound 4 gave a limit, no number; the forecaster's own chance of this, stated with the estimate: 75%; the middle value sits exactly at the limit.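

Compound 4 gives > 150000 nM, which is a limit and not a number. For the compounds shown here, its steps from compound 1, compound 2 and compound 3 therefore cannot be read, and no new step comes from this result. The compounds shown leave open whether these four aryl groups differ at all in this assay, and whether any group at this place on the shared core would give a measurable number.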